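The compounds below may be only part of what the source reports. "The series", "measured", "known", "first", "only" and "open" are said of these compounds alone.

Working notes on the series. Within the data shown here, compound 3 `Cc1ccnc(-c2cnc(C(=O)CCCCCCc3ccccc3)o2)c1` stands lowest of the three numbers so far: in an assay (Rattus norvegicus) for inhibition of Fatty-acid amide hydrolase 1 (Homo sapiens) (a lower number here means a stronger inhibitor, a higher number a weaker inhibitor), compound 3 gives 0.6 nM. Compound 1 `O=C(CCCCCCc1ccccc1)c1ncc(-c2cccc(O)c2)o1` gives 50 nM in this assay, and compound 2 `N#Cc1ccc(-c2cnc(C(=O)CCCCCCc3ccccc3)o2)cc1` gives 40 nM in this assay; the step of a 1.3-fold lower number from compound 1 to compound 2 (0.10 log units; within the scatter) is within the scatter, so no order between compound 1 and compound 2 is read from it. The two steps onto compound 3 are large: an 83-fold lower number from compound 1 to compound 3 (1.92 log units; beyond the scatter) and a 67-fold lower number from compound 2 to compound 3 (1.82 log units; beyond the scatter).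

Compound 4 `O=C(CCCCCCc1ccccc1)c1ncc(-c2ncccc2C(=O)O)o1` is not yet measured. Its change from compound 3 is 3-carboxypyridin-2-yl in place of 4-methylpyridin-2-yl on an aromatic carbon. Among the measured compounds shown here, no measured step exchanges a methyl for a carboxy on the pyridin-2-yl ring, so nothing in the data speaks directly to this change. What the steps show is that the pyridin-2-yl bearing compound 3 sits far below the two phenyl-type compounds 1 and 2, and compound 4 keeps the pyridin-2-yl ring. The expectation is therefore that compound 4 lands somewhere between compound 3 and the phenyl pair, closer to neither with confidence; the step of a 25-fold higher number from compound 3 to compound 4 (1.40 log units; beyond the scatter) is an estimate of moderate loss. Compound 4 is estimated at 15 nM in this assay, with a range from 1.5 nM to 150 nM.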

Compound 4, inhibition constant: > 50 nM
Compound 4: no number, only a limit (the forecaster's own chance of this, stated with the estimate: 5%); at least 3.3-fold (0.52 log units) between middle value and limit.
By their numbers in this assay, from the lowest: compound 3; then compounds 2 and 1 (each within the scatter of the next).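

Compound 4 carries no number in this assay, only a limit of the assay: the limit of > 50 nM in this assay, at which 1 of the 4 values shown sits. Even so, keeping a pyridin-2-yl ring is not enough to retain the low number of compound 3: with 3-carboxypyridin-2-yl in place of 4-methylpyridin-2-yl on this aromatic carbon, next to the ring oxygen, the change is an at least 83-fold higher number from compound 3 to compound 4 (1.92 log units; beyond the scatter), so what the ring bears matters here as well as the ring itself. The comparison with the phenyl-type groups is much less firm: the step of an at least 1.2-fold higher number from compound 2 to compound 4 (0.09 log units; that floor lies within the scatter) has only a floor, and the step of a number no lower from compound 1 to compound 4 (the limit leaves the size open) cannot be read, so compound 4 is given no place relative to either.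

The compounds shown do not separate the loss of the methyl from the arrival of the carboxylic acid, since both happen in the one change and the two groups also differ in where they sit on the ring. An unsubstituted pyridin-2-yl would address the first point, and a methyl ester or a primary amide in place of the carboxylic acid would show whether the loss follows the acid itself or any carbonyl group at that place.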